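Swapping a Fused Benzothiazole for a Nitrothiazole

The source may hold more compounds than are shown below. What is called first, only, known or untested is meant among the compounds shown, and "the series" means these compounds.

Compound 1, `Cc1c(NC(=O)COc2ccc(/C=C3\SC(=O)NC3=O)cc2)c(=O)n(-c2ccccc2)n1C`, gives < 100000 nM in a functional assay on K562 cells (Homo sapiens) for cytotoxicity, read by sulforhodamine B assay, with a stated time of 48 h; a lower number here means a stronger inhibitor of growth, a higher number a weaker inhibitor of growth; this is a limit of the assay.
Compound 2, `Cc1cnc(NC(=O)COc2ccc(/C=C3\SC(=O)NC3=O)cc2)s1`, gives 2240 nM in this assay.
Compound 3, `O=C(COc1ccc(/C=C2\SC(=O)NC2=O)cc1)Nc1nc2ccccc2s1`, gives < 100000 nM in this assay; this is a limit of the assay.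

Compound 3 therefore stands only at a limit and not at a number, sharing that position with another value shown (the limit of < 100000 nM in this assay, at which 2 of the 3 values shown sit). The step from compound 2 to compound 3, a step that the limit leaves unreadable from compound 2 to compound 3, cannot be sized. Compound 4, `O=C(COc1ccc(/C=C2\SC(=O)NC2=O)cc1)Nc1ncc([N+](=O)[O-])s1`, differs from compound 3 by 5-nitro-1,3-thiazol-2-yl in place of 1,3-benzothiazol-2-yl on an amide-type nitrogen. Among the compounds with values here, no measured step covers this exchange. Within the data shown here, the only neighbour with a number is compound 2, which also carries a small thiazole and gives 2240 nM. Compound 4 is expected to land nearer that number than at the limit, with wide uncertainty. The estimate for compound 4 is 4000 nM, between 600 nM and 40000 nM, meaning an expected step that the limit leaves unreadable from compound 3 to compound 4.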

Compound 4, concentration for 50% growth inhibition: < 100000 nM
Compound 4 gave a limit, no number (the forecaster's own chance of this, stated with the estimate: 30%); the middle value is on the limit's open side.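

Compound 4 also gives only a limit of the assay, so its steps from compound 2 and from compound 3 cannot be read: the limit of < 100000 nM in this assay, at which 3 of the 4 values shown sit. Where compound 3 and compound 4 truly stand relative to compound 2, the only compound here with a number, remains open.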